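The source may report more compounds than this note shows. Statements on the series, on what has been measured and on what is new or still open speak of the compounds shown alone.

Compound 1 `Cc1cccc(C#CCOc2cccnc2)n1` stands at the edge of what can be read in a functional assay with metabotropic glutamate receptor 5 (Homo sapiens) as the target, read by FLIPR; a lower number here means a stronger inhibitor, a higher number a weaker inhibitor: in this assay compound 1 gives > 10000 nM, which is a limit of the assay and not a number (the limit of > 10000 nM in this assay, at which 1 of the 2 values shown sits). Compound 2 `Cc1ccc(OCC#Cc2cccc(C)n2)cn1` carries a methyl in place of hydrogen on an aromatic carbon, and in this assay compound 2 gives 2490 nM. For the measured compounds named here, the only measured step is an at least 4.0-fold lower number from compound 1 to compound 2 (0.60 log units; beyond the scatter), and since compound 1 sits at a limit, its true size is unknown. Compound 3 `COC(=O)c1cncc(OCC#Cc2cccc(C)n2)c1` differs from compound 1 in one place: methoxycarbonyl in place of hydrogen on an aromatic carbon. The step to compound 2 concerns a different group, so it bears only loosely on compound 3, and nothing measured shows what methoxycarbonyl does here. Compound 3 is therefore expected to show a step of an at least 1.6-fold lower number from compound 1 to compound 3 (0.22 log units; that floor lies within the scatter), with an estimated value of 6000 nM, likely between 1500 nM and 20000 nM.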

Compound 3, half-maximal inhibitory concentration: 1490 nM
For compound 3 the middle estimate is 4.0-fold (0.60 log units) above the measured one; measured number outside the range, below it.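

Methoxycarbonyl on an aromatic carbon two atoms from the ring nitrogen gives an at least 6.7-fold lower number from compound 1 to compound 3 (0.82 log units; beyond the scatter), so this place on the core of compound 1 accepts a group of 4 heavy atoms without losing activity. The step shown earlier concerned only a methyl at a different place and said nothing about this carbon or about a group with a double bond outside the aromatic rings. Compound 1 stands at a limit of the assay, so the true size of the new step remains unknown: the limit of > 10000 nM in this assay, at which 1 of the 3 values shown sits.

What the compounds shown leave open is how a carboxylic acid, a primary amide or an ethoxycarbonyl group would read on this same carbon in this assay. They also leave open whether a plain methyl here would give a similar step.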